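This account rests on a few compounds, and the source may have more. Where it says the series, first, only, none or still open, it means among the compounds named here.

Measured compounds:
Compound 1 `O=C1Nc2ccccc2[C@]12N[C@H](c1ccccc1)[C@H](c1cccs1)[C@@]21CCc2c([nH]c3ccccc23)C1=O` gives 16000 nM in a functional assay on A549 cells (Homo sapiens) for antiproliferative activity, read by MTT assay, with a stated time of 48 h; on this read-out lower numbers stand for stronger inhibition and higher numbers for weaker inhibition.
Compound 2 `COc1ccc([C@H]2[C@@H](c3ccccc3)N[C@@]3(C(=O)Nc4ccccc43)[C@]23CCc2c([nH]c4ccc(Cl)cc24)C3=O)cc1` gives 18000 nM in this assay.

Compound 2 has the highest of the two numbers, but compound 1 stands within the scatter of it. Going by the values given here, compound 3 `COc1ccc([C@H]2[C@@H](c3ccccc3)N[C@@]3(C(=O)Nc4ccccc43)[C@]23CCc2c([nH]c4ccccc24)C3=O)cc1` differs from compound 2 by hydrogen in place of chloro on an aromatic carbon; no measured pair shows this change on its own. Given that compound 1, also lacking the chloro, gives 16000 nM, compound 3 is expected to stay close to compound 2, a step of a 1.1-fold lower number from compound 2 to compound 3 (0.02 log units; within the scatter) of no size beyond the scatter in either direction. For compound 3 the estimate in this assay is 17000 nM, ranging from 7000 nM to 40000 nM.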

Compound 3, half-maximal inhibitory concentration: 21000 nM
For compound 3 the middle estimate is 1.2-fold (0.09 log units) below the measured one; the measured number falls inside the stated range.
By their numbers in this assay, from the lowest: compounds 1, 2 and 3 (each within the scatter of the next).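

In this assay, going by these compounds alone, hydrogen in place of chloro on this aromatic carbon gives the first reading of that change on its own (a 1.2-fold higher number from compound 2 to compound 3 (0.07 log units; within the scatter)), and the chloro makes no difference beyond the scatter. The 4-methoxyphenyl in place of thiophen-2-yl on a saturated ring carbon also stays within the scatter (a 1.3-fold higher number from compound 1 to compound 3 (0.12 log units; within the scatter)). No available measurement offers an explanation for either result. The compounds shown leave open whether an amine or a carboxylic acid on the same aromatic carbon would shift the number beyond the scatter.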